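From a Methylphenyl Amide to a Dimethoxyphenyl Amide

A few compounds are considered here, and "the series" means these few. Any claim that something is new, unique, unknown or untested is made for them only; others in the source may bear on it.

Of the compounds shown here, two have so far been tested in a functional assay on HCC1937 cells (Homo sapiens) for antiproliferative activity, read by CCK-8 assay, with a stated time of 72 h; a higher number here means a weaker inhibitor, a lower number a stronger inhibitor. Compound 1 `Cc1ccccc1C(=O)Nc1cccc(-c2oc3cc(-c4ccc(F)cc4)ccc3c(=O)c2O)c1` gives 9900 nM in this assay. Compound 2 `Cc1cccc(C(=O)Nc2cccc(-c3oc4cc(-c5ccc(F)cc5)ccc4c(=O)c3O)c2)c1` gives 8030 nM. Going by the values given here, the single measured step, a 1.2-fold lower number from compound 1 to compound 2 (0.09 log units; within the scatter), shifts only a methyl group on the amide's phenyl ring and does not rise above the scatter. Compound 2 therefore holds the lower of the two numbers, but its gap to compound 1 is within the scatter, so the two compounds cannot be told apart in this assay.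

Compound 3 `COc1cc(OC)cc(C(=O)Nc2cccc(-c3oc4cc(-c5ccc(F)cc5)ccc4c(=O)c3O)c2)c1` has not yet been measured. It differs from compound 2 by 3,5-dimethoxyphenyl in place of 3-methylphenyl on a carbonyl carbon. Among the compounds with values here, no measured step touches this exchange: the one step on record concerns a methyl shift, not a change to methoxy groups, and it was itself within the scatter. With nothing pointing to a shift in either direction, compound 3 is expected to land close to compound 2, and the expected step of a 1.1-fold lower number from compound 2 to compound 3 (0.03 log units; within the scatter) is estimated to stay within the scatter. Compound 3 is estimated at 7500 nM in this assay, with a range from 2500 nM to 22000 nM.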

Compound 3, half-maximal inhibitory concentration: 6250 nM
Estimate against measurement, compound 3: 1.2-fold (0.08 log units) above, and the stated range covers the measured number.
By their numbers in this assay, from the lowest: compounds 3, 2 and 1 (each within the scatter of the next).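

On the carbonyl carbon of the amide, the change from 3-methylphenyl to 3,5-dimethoxyphenyl is larger than the earlier shift of a methyl group: the group grows from 7 to 10 heavy atoms and gains 2 hydrogen-bond acceptors. Even so, the step in this assay is a 1.3-fold lower number from compound 2 to compound 3 (0.11 log units; within the scatter) and does not rise above the scatter. Set against the other methylphenyl amide, the same group gives a 1.6-fold lower number from compound 1 to compound 3 (0.20 log units; within the scatter) and so also stays within the scatter, which means that these three phenyl amides cannot be told apart here and that adding two methoxy groups at this position brings no readable difference; nothing available on these compounds offers an explanation for this result.

From the compounds shown here alone, the three compounds all carry a substituted phenyl ring on this carbonyl carbon, so it remains open whether a different kind of group, such as an amine, a carboxylic acid or a longer alkyl chain, would move the number beyond the scatter. Going by these compounds, it is also open whether a single methoxy group, or a halogen such as chlorine, on the same ring would do so.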